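Swapping Benzamido for Fluoro in a Cytotoxicity Series

The source may hold more compounds than are shown below. What is called first, only, known or untested is meant among the compounds shown, and "the series" means these compounds.

Compound 1 `COC(=O)c1cc(C2=C(c3cc(OC)c(OC)c(OC)c3)C(=O)CC2O[SiH2]C(C)(C)C)ccc1OC` gives in an ADME assay on DU-145 cells (Homo sapiens) for cytotoxicity, read by MTT assay, with a stated time of 72 h (a higher number here means a weaker inhibitor, a lower number a stronger inhibitor), only the limit > 100 ug/mL.
Compound 2 `COc1ccc(C2=C(c3cc(OC)c(OC)c(OC)c3)C(=O)C(O)C2)cc1NC(=O)c1ccccc1` gives in this assay only the limit > 100 ug/mL.
Compound 3 `COc1ccc(C2=C(c3cc(OC)c(OC)c(OC)c3)C(=O)CC2O[SiH2]C(C)(C)C)cc1O` gives in this assay 75 ug/mL.

Compound 2 therefore stands at the upper edge of what this assay reports, the same limit noted for compound 1 in the limit of > 100 ug/mL in this assay, at which 2 of the 3 values shown sit, and only compound 3 returns a number. The single measured step among these compounds, an at least 1.3-fold lower number from compound 1 to compound 3 (0.12 log units; that floor lies within the scatter), concerns hydroxy in place of methoxycarbonyl on an aromatic carbon, and its size lies within the scatter.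

Compound 4 `COc1ccc(C2=C(c3cc(OC)c(OC)c(OC)c3)C(=O)C(O)C2)cc1F` differs from compound 2 by fluoro in place of benzamido on an aromatic carbon. Among the measured compounds shown here, no measured step matches this exchange, and the one step that exists was small and started from a limit, so it gives little guidance on direction. The limit for compound 2 means that only a move to a measurable number would register at all.

Compound 4 is expected to give about 60 ug/mL in this assay, estimated to fall between 20 ug/mL and 150 ug/mL. The implied step, an at least 1.6-fold lower number from compound 2 to compound 4 (0.22 log units; that floor lies within the scatter), is expected to be modest and possibly not to emerge from the scatter.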

Compound 4, half-maximal inhibitory concentration: 27 ug/mL
For compound 4 the middle estimate is 2.2-fold (0.35 log units) above the measured one; the measured number falls inside the stated range.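

Among the compounds shown here, at this position, on an aromatic carbon ortho to a methoxy group, the exchange of benzamido for fluoro gives the first step in this assay that clears the scatter: an at least 3.7-fold lower number from compound 2 to compound 4 (0.56 log units; beyond the scatter). The earlier change at the same kind of position, an at least 1.3-fold lower number from compound 1 to compound 3 (0.12 log units; that floor lies within the scatter), could not show this, so the series now holds its first sign that the group on this carbon can move the number beyond ordinary repeat variation. The entry for compound 2 is a limit and not a number, which makes the new step a floor whose full size stays unknown: the limit of > 100 ug/mL in this assay, at which 2 of the 4 values shown sit.

Going by these compounds, what remains open is whether the lower number follows from the loss of benzamido, from the arrival of fluoro, or from both, a question that an amine, a chloro group or an acetamido group on this same carbon would help to settle. Also open, on these data alone, is whether fluoro on this carbon would give a similar step on the core of compound 3, whose other substituents differ from those of compound 4.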